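The compounds below may be only part of what the source reports. "The series", "measured", "known", "first", "only" and "open" are said of these compounds alone.

Measured in an assay on BTI cells for inhibition of Amine oxidase [flavin-containing] B (Homo sapiens), read by fluorescence and Amplex Red, with a stated time of 15 min; a higher number here means a weaker inhibitor, a lower number a stronger inhibitor:
compound 1 `CC(=O)N1N=C(c2ccncc2)OC1c1ccc(Cl)c(Cl)c1` gives 69400 nM
compound 2 `CC(=O)N1N=C(c2ccc(C)cc2)OC1c1ccc(Cl)c(Cl)c1` gives 19.4 nM
compound 3 `CC(=O)N1N=C(c2ccc(Cl)cc2)OC1c1ccc(Cl)c(Cl)c1` gives 627 nM

Compound 3 stands second highest of the three numbers, set apart from compound 2 by a 32-fold higher number from compound 2 to compound 3 (1.51 log units; beyond the scatter) and from compound 1 by a 110-fold lower number from compound 1 to compound 3 (2.04 log units; beyond the scatter). Compound 4 `COc1ccc(C2=NN(C(C)=O)C(c3ccc(Cl)c(Cl)c3)O2)cc1` differs from compound 3 by methoxy in place of chloro on an aromatic carbon. Going by the values given here, no measured step introduces a methoxy group; the only step at this aromatic carbon is a 32-fold higher number from compound 2 to compound 3 (1.51 log units; beyond the scatter), chloro in place of methyl, a large step. Replacing chloro by another small uncharged group that is not chloro is therefore expected to lower the number beyond the scatter, though how far toward compound 2 is open. Compound 4 is estimated at 120 nM, range 25 nM to 600 nM, an expected step of a 5.2-fold lower number from compound 3 to compound 4 (0.72 log units; beyond the scatter).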

Compound 4, half-maximal inhibitory concentration: 218 nM
Beside the measured number, compound 4's estimate is 1.8-fold (0.26 log units) below it, within the range that was stated.
By their numbers in this assay, from the lowest: compound 2; then compound 4; then compound 3; then compound 1.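

In this assay, methoxy on this aromatic carbon improves on chloro, a 2.9-fold lower number from compound 3 to compound 4 (0.46 log units; beyond the scatter), but falls short of methyl, an 11-fold higher number from compound 2 to compound 4 (1.05 log units; beyond the scatter), so the three groups now separate in the order methyl, methoxy, chloro, with each gap beyond the scatter. The 4-methoxyphenyl group also stands far from pyridin-4-yl, a 320-fold lower number from compound 1 to compound 4 (2.50 log units; beyond the scatter), as the other two phenyl groups do. Nothing available explains this order.

Going by these compounds, whether an amine or a longer chain such as ethyl on this carbon would match or pass compound 2 remains open.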